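The compounds below may be only part of what the source reports. "The series", "measured", "known", "first", "only" and "open" are said of these compounds alone.

Of the compounds shown here, two have so far been tested in a functional assay on MDA-MB-231 cells (Homo sapiens), read by wound healing assay, with a stated time of 24 h; on this read-out higher numbers stand for weaker inhibition and lower numbers for stronger inhibition. Compound 1 `CC(C)=CCC[C@H](C)c1ccc(C)c(CNCC2CCNCC2)c1O` gives > 20000 nM, and this value is a limit of the assay, not a number. Compound 2 `CC(C)=CCC[C@H](C)c1ccc(C)c2c1OCN(CCCCCO)C2` gives 10000 nM in this assay. Among the measured compounds shown here, that is the only true number available, and the one other reading is the limit, so compound 2 has no measured number to be ranked against.

Compound 3 `CCOC(CCN1COc2c([C@@H](C)CCC=C(C)C)ccc(C)c2C1)OCC` has not yet been measured. Its structure departs from that of compound 2 in one place: diethoxymethyl in place of 3-hydroxypropyl on a saturated chain carbon, two bonds along the chain from an amine nitrogen in a ring. Cut one bond further out, the same difference reads 5-hydroxypentyl to 3,3-diethoxypropyl.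

For the measured compounds named here, no pair of measured compounds shows what a change of this kind does in this assay, so any forecast here is uncertain. Only a small move towards weaker inhibition is expected, of a size that may not exceed the usual scatter of the assay. The expected step is a 1.2-fold higher number from compound 2 to compound 3 (0.08 log units; within the scatter). Compound 3 is estimated at 12000 nM. The expected range for compound 3 runs from 5000 nM to 28000 nM.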

Compound 3, half-maximal inhibitory concentration: 3100 nM
Beside the measured number, compound 3's estimate is 3.9-fold (0.59 log units) above it; the measured number lies below the stated range.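

In this assay, placing diethoxymethyl in place of 3-hydroxypropyl, on a saturated chain carbon, two bonds along the chain from an amine nitrogen in a ring, gives a 3.2-fold lower number from compound 2 to compound 3 (0.51 log units; beyond the scatter), the first measured effect of any change at this place. In this pair, the chain need not end in the hydroxyl of 5-hydroxypentyl to keep inhibition in this assay: 3,3-diethoxypropyl, with 0 hydrogen-bond donors in the entering diethoxymethyl, gives the lower number. Both compounds in this step carry true numbers rather than the one reading in the set that is a limit: the limit of > 20000 nM in this assay, at which 1 of the 3 values shown sits.

This single pair cannot tell whether the lower number goes with the loss of the hydroxyl or with the arrival of the two ethoxy groups, and a chain ending in one methoxy group, an amine or a carboxylic acid would help to separate the two. On these data alone, it also remains open whether a longer chain ending in the same two ethoxy groups would keep, lower or raise the number in this assay.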